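Glycosyl triazole indoles and an untested larger side group

The source may hold more compounds than are shown below. What is called first, only, known or untested is meant among the compounds shown, and "the series" means these compounds.

Compounds 1, 2 and 3 share a sugar-bearing triazole linked to an indole-type core. Compound 1 `COc1ccc2c(c1)c(C=O)cn2Cc1cn([C@@H]2O[C@H](COC(C)=O)[C@@H](OC(C)=O)[C@H](OC(C)=O)[C@H]2OC(C)=O)nn1` gives 136000 nM in a functional assay on DU-145 cells (Homo sapiens) for cytotoxicity, read by sulforhodamine B assay, with a stated time of 48 h (on this read-out lower numbers stand for stronger inhibition and higher numbers for weaker inhibition), compound 2 `COc1ccc2c(c1)c(/C=N/O)cn2Cc1cn([C@@H]2O[C@H](COC(C)=O)[C@@H](OC(C)=O)[C@H](OC(C)=O)[C@H]2OC(C)=O)nn1` gives 88400 nM, and compound 3 `CC(=O)OC[C@H]1O[C@@H](n2cc(Cn3cc([N+](=O)[O-])c4ccccc43)nn2)[C@H](OC(C)=O)[C@@H](OC(C)=O)[C@@H]1OC(C)=O` gives 60900 nM, the lowest number of the three: compound 2 lies within the scatter of it, compound 1 beyond it. Going by the values given here, the only measured step, a 1.5-fold lower number from compound 1 to compound 2 (0.19 log units; within the scatter), changed a small group at a different position and was within the scatter, so it says little about compound 4 `CC(=O)OC[C@H]1O[C@@H](n2cc(Cn3cc(/C=C4/C(=O)Nc5ccccc54)c4ccccc43)nn2)[C@H](OC(C)=O)[C@@H](OC(C)=O)[C@@H]1OC(C)=O`, where (a group of 11 heavy atoms (9 carbon, 1 nitrogen, 1 oxygen; one five-membered non-aromatic ring with 1 hetero atom, one six-membered aromatic ring of carbon only) in place of a group of 3 heavy atoms (1 nitrogen, 2 oxygen; no ring), on an aromatic carbon). Among the compounds with values here, with a change this large and no matching precedent, compound 4 is expected to give a modestly lower number, a 2.0-fold lower number from compound 3 to compound 4 (0.31 log units; beyond the scatter), estimated at 30000 nM, within a broad range from 7000 nM to 130000 nM.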

Compound 4, half-maximal inhibitory concentration: > 200000 nM
Compound 4: a limit, no number; the forecaster's own chance of this, stated with the estimate: 10%; middle value at least 6.6-fold (0.82 log units) away from the limit.
By their numbers in this assay, from the lowest: compounds 3, 2 and 1 (each within the scatter of the next, the first and the last beyond it). At a limit, above all of these: compound 4.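

In this assay, compound 4 gives > 200000 nM, which is a limit and not a number: the limit of > 200000 nM in this assay, at which 1 of the 4 values shown sits.

Even so, the exchange of the nitro for the larger group can be read as an at least 3.2-fold higher number from compound 3 to compound 4 (0.51 log units; beyond the scatter). Unlike the earlier step, this one lies beyond the scatter, so the number does respond to what sits at this position.

Where compound 4 truly lies past its limit stays open. So does whether a small group here, such as an amine or a nitrile, would give a number lower or higher than that of compound 3.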